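Moving the fluorine on the benzamide of a chemokine receptor ligand

The source may hold more compounds than are shown below. What is called first, only, known or untested is meant among the compounds shown, and "the series" means these compounds.

Measured so far:
compound 1 `CC(C)C(NS(=O)(=O)Cc1ccccc1)C(=O)N1CCC(c2ccc(Cl)cc2)CC1`, 303 nM
compound 2 `CC(C)[C@@H](NC(=O)c1cccc(F)c1)C(=O)N1CCC(c2ccc(Cl)cc2)CC1`, 24 nM

In an assay on THP-1 cells for displacement of a labelled ligand from C-C chemokine receptor type 1 (Homo sapiens) (on this read-out higher numbers stand for weaker inhibition and lower numbers for stronger inhibition), compound 2 gives the lower of the two numbers, and its gap to compound 1 lies beyond the usual scatter. Compound 3 `CC(C)[C@@H](NC(=O)c1ccc(F)cc1)C(=O)N1CCC(c2ccc(Cl)cc2)CC1` is not yet measured; it differs from compound 2 by 4-fluorophenyl in place of 3-fluorophenyl on a carbonyl carbon. Within the data shown here, no measured pair shows this kind of change, so the step has to be guessed from compound 2 alone. The expectation is a step from compound 2 to compound 3 of a 1.5-fold higher number from compound 2 to compound 3 (0.16 log units; within the scatter), a small weakening that may not exceed the scatter. Compound 3 is expected to give about 35 nM, within 12 nM to 100 nM.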

Compound 3, half-maximal inhibitory concentration: 118 nM
Compound 3: middle estimate off by 3.4-fold (0.53 log units), on the low side, outside the stated range (above it).
By their numbers in this assay, from the lowest: compound 2; then compound 3; then compound 1.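

Replacing 3-fluorophenyl with 4-fluorophenyl on a carbonyl carbon keeps the same atoms, yet in this assay it gives a 4.9-fold higher number from compound 2 to compound 3 (0.69 log units; beyond the scatter). The number at this position therefore depends on where the fluorine sits on the ring, something the gap between compound 1 and compound 2 could not show. Nothing available explains why this shift matters. On these data alone, whether plain phenyl, a pyridine ring or a cyclohexyl group on the carbonyl carbon would give a lower or higher number than 3-fluorophenyl stays open.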